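Moving the chlorine on the phenyl ring of compound 3

A few compounds are considered here, and "the series" means these few. Any claim that something is new, unique, unknown or untested is made for them only; others in the source may bear on it.

Compound 3 `OC(CCn1nc2c(Br)c(Br)c(Br)c(Br)c2n1)c1cccc(Cl)c1` gives 28% in a functional assay on MCF7 cells (Homo sapiens) for antiproliferative activity, read by MTT assay, with a stated time of 24 h, tested at 50 uM; a higher number here means a weaker effect of the compound at the concentration tested, a lower number a stronger effect. That puts compound 3 second highest of the three numbers: compound 2 `OC(CCn1nc2c(Br)c(Br)c(Br)c(Br)c2n1)c1ccc(Br)cc1` lies closest with 10%, and compound 1 `OCC(O)Cn1nc2c(Br)c(Br)c(Br)c(Br)c2n1` furthest with 98%. Compound 4 `OC(CCn1nc2c(Br)c(Br)c(Br)c(Br)c2n1)c1ccc(Cl)cc1` differs from compound 3 by 4-chlorophenyl in place of 3-chlorophenyl on a saturated chain carbon bound to an oxygen on a saturated carbon and a saturated chain carbon. Among the compounds with values here, the only measured step that touches this part of the molecule is a number 18 percentage points higher from compound 2 to compound 3 (beyond the scatter), where a 4-bromophenyl gave the stronger effect. Since compound 4 carries its chlorine as a 4-chlorophenyl, the step from compound 3 is expected to run back toward compound 2, giving a number 13 percentage points lower from compound 3 to compound 4 (beyond the scatter). Compound 4 is therefore estimated at 15%, within a range of 5% to 35%.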

Compound 4, a percentage reported as activity, at one concentration (the size of the read-out at that concentration, not a potency): 19%
Compound 4: middle estimate off by 4 percentage points, on the low side; the range from low to high includes it.
By their numbers in this assay, from the lowest: compounds 2, 4 and 3 (each within the scatter of the next, the first and the last beyond it); then compound 1.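

Taken one at a time, the two changes are small: 4-chlorophenyl in place of 3-chlorophenyl gives a number 9 percentage points lower from compound 3 to compound 4 (within the scatter) in this assay and chloro in place of bromo gives a number 9 percentage points higher from compound 2 to compound 4 (within the scatter) there. Only the earlier step, a number 18 percentage points higher from compound 2 to compound 3 (beyond the scatter) and which changed both the halogen and its place on the ring, lies beyond the scatter. No supporting measurement explains why these changes add up this way.

Still open, on these data alone, is whether an amine or a carboxylic acid on the phenyl ring would keep this effect. A longer chain to the shared core also remains to be judged.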